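The source may report more compounds than this note shows. Statements on the series, on what has been measured and on what is new or still open speak of the compounds shown alone.

In a functional assay on PC-3 cells (Homo sapiens) for cytotoxicity, read by MTT assay, with a stated time of 72 h (on this read-out lower numbers stand for stronger inhibition and higher numbers for weaker inhibition), three compounds sharing one core have been measured. Compound 1 `CC1=C(/C=C/C(=O)/C=C/c2ccc(C(F)(F)F)cc2)C(C)(C)CCC1` gives 12000 nM in this test, and compound 2 `CC1=C(/C=C/C(=O)/C=C/c2cc(C(F)(F)F)cc(C(F)(F)F)c2)C(C)(C)CCC1` gives 7200 nM there, so the two numbers lie within the usual scatter of each other. For compound 3 `CC1=C(/C=C/C(=O)/C=C/c2ccc(O)c([N+](=O)[O-])c2)C(C)(C)CCC1` the result is > 50000 nM as a limit of the test and not a number. Compound 2 therefore stands level with compound 1 among the two true numbers. Compound 4 `CC1=C(/C=C/C(=O)/C=C/c2cc(C(F)(F)F)cc(C(F)(F)F)c2)C(C)(C)CCC1O` differs from compound 2 by hydroxy in place of hydrogen on a saturated ring carbon, counted as hydroxy in place of hydrogen on a saturated ring carbon in full. For the measured compounds named here, no measured pair isolates this change. Going by the values given here, the only guide is compound 3 at > 50000 nM as the one measured compound with a hydroxy group, although it differs in other places too. In this assay a modest move toward a higher number is therefore expected, and it may not exceed the scatter. The estimated change is a 1.8-fold higher number from compound 2 to compound 4 (0.26 log units; within the scatter) overall. For compound 4 the expected value is 13000 nM with an estimated range from 5000 nM to 40000 nM in this test.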

Compound 4, half-maximal inhibitory concentration: 7000 nM
Beside the measured number, compound 4's estimate is 1.9-fold (0.27 log units) above it; measured number inside the range.
By their numbers in this assay, from the lowest: compounds 4, 2 and 1 (each within the scatter of the next). At a limit, above all of these: compound 3.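

In this assay, for the compounds shown here, the step reads a 1.0-fold lower number from compound 2 to compound 4 (0.01 log units; within the scatter), and it is the first measured pair that isolates hydroxy in place of hydrogen on a saturated ring carbon. The 2,6,6-trimethylcyclohex-1-en-1-yl group can therefore be replaced by 3-hydroxy-2,6,6-trimethylcyclohex-1-en-1-yl, with the hydroxy next to the ring atom that bears a methyl group, without the number leaving the scatter of compound 2. Compound 3 also carries a hydroxy group, but elsewhere and with other differences, and its result is a limit and not a number: the limit of > 50000 nM in this assay, at which 1 of the 4 values shown sits.

This is a single pair at a single ring carbon, so it cannot be said whether the same holds for hydroxy on the core of compound 1. Also open, from the compounds shown here alone, is how an amine, a methoxy group or a carbonyl on this ring carbon would read in this assay.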